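The source may report more compounds than this note shows. Statements on the series, on what has been measured and on what is new or still open speak of the compounds shown alone.

Of the compounds shown here, two built on a shared core have been measured in a functional assay on OVCAR-5 cells (Homo sapiens) for inhibition, read by sulforhodamine B assay, with a stated time of 48 h; on this read-out lower numbers stand for stronger inhibition of growth and higher numbers for weaker inhibition of growth. Compound 1 `COc1ccc(-c2cc(/C=C/C(=O)c3ccc(N)cc3)[nH]n2)cc1` gives 2060 nM in this assay. Compound 2 `COc1cc(-c2cc(/C=C/C(=O)c3ccc(N)cc3)[nH]n2)cc(OC)c1OC` gives 1780 nM in this assay. These two numbers lie within the usual scatter of repeated measurements of each other, so neither compound can be set apart from the other on this evidence. Compound 3 `COc1ccc(-c2cc(/C=C/C(=O)c3ccc(N)cc3)[nH]n2)cc1OC` has not yet been measured. It differs from compound 2 in one place: hydrogen in place of methoxy on an aromatic carbon. For the measured compounds named here, no step between measured compounds that differ in one place is available, so the expectation for this change rests only on how close compound 1 and compound 2 sit. On that basis the expected step in this assay is a 1.1-fold higher number from compound 2 to compound 3 (0.03 log units; within the scatter), nothing beyond the scatter. Compound 3 is therefore estimated at 1900 nM in this assay, with a range from 900 nM to 4000 nM.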

Compound 3, concentration for 50% growth inhibition: 2620 nM
Estimate against measurement, compound 3: 1.4-fold (0.14 log units) below; measured number inside the range.
By their numbers in this assay, from the lowest: compounds 2, 1 and 3 (each within the scatter of the next).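

With the methoxy on this aromatic carbon of compound 2 replaced by hydrogen, this assay shows a 1.5-fold higher number from compound 2 to compound 3 (0.17 log units; within the scatter) and so no measurable effect of the swap. The opposite swap, methoxy in place of hydrogen, gives a 1.3-fold higher number from compound 1 to compound 3 (0.10 log units; within the scatter) and so also stays inside the scatter, which means that across these compounds the ring carries one, two or three methoxy groups with no separable difference in growth inhibition. No measurement here offers an explanation for this flat result.

The compounds shown hold only hydrogen or methoxy at this carbon, so it remains open whether a hydroxyl group, a fluorine atom, an amine or a longer chain such as ethoxy would also sit within the scatter. From the compounds shown here alone, whether the same holds in other cell lines also remains open.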